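Drawing One Stereocentre: From Compound 1 to Compound 4

This account rests on a few compounds, and the source may have more. Where it says the series, first, only, none or still open, it means among the compounds named here.

Measured compounds in a toxicity assay on HEK-293T cells (Homo sapiens) for cytotoxicity, read by MTT assay, with a stated time of 72 h; on this read-out higher numbers stand for weaker inhibition and lower numbers for stronger inhibition:
compound 1, `O=C1c2c[n+]([O-])c3ccccc3c2C(=O)c2c1c1ccccc1n2Cc1cn(CC(O)CO)nn1`, gives 760 nM.
compound 2, `O=C1c2c[n+]([O-])c3ccccc3c2C(=O)c2c1c1ccccc1n2Cc1cn([C@H]2O[C@H](CO)[C@@H](O)[C@H]2O)nn1`, gives 1370 nM.
compound 3, `CN(C)CCCCn1c2c(c3ccccc31)C(=O)c1c[n+]([O-])c3ccccc3c1C2=O`, gives 520 nM.

Compound 1 has the second highest of the three numbers in this assay. Its nearest neighbour is compound 3, and the two are within the scatter of each other, as the step of a 1.5-fold lower number from compound 1 to compound 3 (0.16 log units; within the scatter) shows. Its furthest neighbour is compound 2, yet that gap, a 1.8-fold higher number from compound 1 to compound 2 (0.26 log units; within the scatter), is also within the scatter. So far, then, the three compounds cannot be told apart on this read-out.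

Compound 4, `O=C1c2c[n+]([O-])c3ccccc3c2C(=O)c2c1c1ccccc1n2Cc1cn(C[C@H](O)CO)nn1`, differs from compound 1 only in how one centre is drawn: the two compounds have the same atoms and bonds; at least one stereo element is drawn with a configuration in one of them and without one in the other: 1 of 1 stereo elements differ; a stereocentre at a saturated chain carbon is drawn without a configuration in compound 1 and S in compound 4. No atom is removed and none is added. Neither of the two measured steps involves a stereocentre, and both were within the scatter, so nothing measured points to a shift in either direction. A single drawn configuration of a centre that is otherwise left open can, in principle, move a number a little either way, but here no step beyond the scatter is expected.

Compound 4 is therefore estimated at 700 nM, with a range from 350 nM to 1500 nM, which corresponds to an expected step of a 1.1-fold lower number from compound 1 to compound 4 (0.04 log units; within the scatter).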

Compound 4, half-maximal inhibitory concentration: 8880 nM
The estimate for compound 4 lay 13-fold (1.10 log units) below the measured number, and the stated range ends below it.
By their numbers in this assay, from the lowest: compounds 3, 1 and 2 (each within the scatter of the next, the first and the last beyond it); then compound 4.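

In this assay, among the compounds shown here, the stereocentre of the 2,3-dihydroxypropyl chain matters far more than the earlier compounds suggested: exchanging whole groups had kept every step within the scatter, whereas this change, which adds and removes no atom, gives a 12-fold higher number from compound 1 to compound 4 (1.07 log units; beyond the scatter). Compound 4 also stands clear of the two other compounds, with a 17-fold higher number from compound 3 to compound 4 (1.23 log units; beyond the scatter) and a 6.5-fold higher number from compound 2 to compound 4 (0.81 log units; beyond the scatter), which makes it the weakest inhibitor of the four on this read-out. The structures record only one difference that could lie behind the large step from compound 1: the fact that one of compounds 1 and 4 is drawn with a defined configuration and the other without, at the place where they differ.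

As far as these compounds go, what compound 1 actually contains at that centre remains open, and so does the number that a chain drawn with the R configuration would give, so it cannot yet be said whether the centre's configuration alone accounts for the step. From the compounds shown here alone, it is equally open whether the S chain would keep this high number if a single hydroxyl, a carboxylic acid or an amine stood in place of the two hydroxyl groups of the 2,3-dihydroxypropyl chain.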